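A few compounds are considered here, and "the series" means these few. Any claim that something is new, unique, unknown or untested is made for them only; others in the source may bear on it.

Measured in a functional assay on Raji cells (Homo sapiens); on this read-out lower numbers stand for stronger inhibition and higher numbers for weaker inhibition:
- compound 1 `O=c1[nH]c(=O)n([C@@H]2O[C@H](COP(=O)(O)O)[C@@H](O)[C@H]2O)cc1Br`: the value > 1000 ug/mL is a limit of the assay, not a number
- compound 2 `O=c1[nH]c(=O)n([C@@H]2O[C@@H]3COP(=O)(O)O[C@H]3[C@H]2O)cc1I`: 722 ug/mL
- compound 3 `O=c1[nH]c(=O)n([C@@H]2O[C@@H]3COP(=O)(O)O[C@H]3[C@H]2O)cc1Cl`: 369 ug/mL

Compound 3 has the lowest of the two numbers in this assay; the nearest is compound 2, and the step of a 2.0-fold lower number from compound 2 to compound 3 (0.29 log units; within the scatter) is within the scatter, so no order between the two is claimed. The value of compound 1 sits at the limit of > 1000 ug/mL in this assay, at which 1 of the 3 values shown sits. Compound 4 `O=c1[nH]c(=O)n([C@@H]2O[C@@H]3COP(=O)(O)O[C@H]3[C@H]2O)cc1F` differs from compound 3 only in fluoro in place of chloro on an aromatic carbon. Going by the values given here, the only measured step on a halogen exchange is the one from compound 2 to compound 3, which stayed within the scatter; a further exchange to fluoro is therefore expected to move the number little, if at all, in this assay. Compound 4 is expected at 300 ug/mL, between 100 ug/mL and 1000 ug/mL. That estimate means a step of a 1.2-fold lower number from compound 3 to compound 4 (0.09 log units; within the scatter).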

Compound 4, concentration for 50% inhibition: 1.64 ug/mL
For compound 4 the middle estimate is 180-fold (2.26 log units) above the measured one; measured number below the stated range.
By their numbers in this assay, from the lowest: compound 4; then compounds 3 and 2 (each within the scatter of the next). At a limit, above all of these: compound 1.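

In this assay, this position does respond to halogen exchange: fluoro in place of chloro gives a large step (a 230-fold lower number from compound 3 to compound 4 (2.35 log units; beyond the scatter)), and fluoro in place of iodo gives a similar one (a 440-fold lower number from compound 2 to compound 4 (2.64 log units; beyond the scatter)). The chloro and iodo compounds stay within the scatter of each other and gave no sign of this, so among the halogens shown, only fluoro stands apart. Nothing measured here bears on the cause of this gap. On these data alone, whether the effect is specific to fluoro remains open; hydrogen, a methyl group or an amine at this position would test that.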